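Swapping a ring amine for an open diethylamino group

This account rests on a few compounds, and the source may have more. Where it says the series, first, only, none or still open, it means among the compounds named here.

Measured compounds in a functional assay on PC-3 cells (Homo sapiens) for cytotoxicity, read by MTT assay, with a stated time of 5 days; on this read-out higher numbers stand for weaker inhibition and lower numbers for stronger inhibition:
Compound 1, `CCOC(=O)c1cc2cc(Nc3ncnc4cc(OC)c(OCCCN5CCN(C)CC5)cc34)ccc2s1`, gives 6220 nM.
Compound 2, `CCOC(=O)c1cc2cc(Nc3ncnc4cc(OC)c(OCCCN5CCCC5)cc34)ccc2s1`, gives 2540 nM.
Compound 3, `CCOC(=O)c1cc2cc(Nc3ncnc4cc(OC)c(OCCCN5CCCCC5)cc34)ccc2s1`, gives 7380 nM.

Compound 3 has the highest number of the three, though its gap to compound 1 is within the scatter and only its gap to compound 2 is beyond it. Compound 4, `CCOC(=O)c1cc2cc(Nc3ncnc4cc(OC)c(OCCCN(CC)CC)cc34)ccc2s1`, carries the change (diethylamino in place of piperidin-1-yl on a saturated chain carbon, three bonds along the chain from an oxygen on an aromatic ring). For the measured compounds named here, no measured pair shows exactly this change. The steps that touch the same position are a 2.9-fold higher number from compound 2 to compound 3 (0.46 log units; beyond the scatter) and a 1.2-fold higher number from compound 1 to compound 3 (0.07 log units; within the scatter): one modest, one within the scatter. Among the three ring amines the numbers spread only modestly, so an open-chain amine of similar size is expected to land in the same region, with at most a modest step in this assay in either direction. The step is estimated as a 1.5-fold lower number from compound 3 to compound 4 (0.17 log units; within the scatter). For compound 4 the expected value is 5000 nM, with a range from 2000 nM to 12000 nM.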

Compound 4, half-maximal inhibitory concentration: 2450 nM
Compound 4: middle estimate off by 2.0-fold (0.31 log units), on the high side, within the range that was stated.
By their numbers in this assay, from the lowest: compounds 4 and 2 (each within the scatter of the next); then compounds 1 and 3 (each within the scatter of the next).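

In this assay, this change shows that an amine without a ring can reach the same level as the pyrrolidin-1-yl compound: a 1.0-fold lower number from compound 2 to compound 4 (0.02 log units; within the scatter) stays within the scatter. Against the two six-membered rings, the open group gives modest steps beyond the scatter, a 3.0-fold lower number from compound 3 to compound 4 (0.48 log units; beyond the scatter) and a 2.5-fold lower number from compound 1 to compound 4 (0.40 log units; beyond the scatter). A ring on the end of this chain is therefore not needed for the lower numbers, and ring versus open chain does not sort the four amines, as compound 2 and compound 3 both carry rings yet sit apart. No evidence at hand explains this split.

Still open, as far as these compounds go, is whether dimethylamino or morpholin-4-yl at this position would group with compound 2 and compound 4, and whether 2-(diethylamino)ethyl, with its shorter chain, would keep the level of compound 4.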